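This account rests on a few compounds, and the source may have more. Where it says the series, first, only, none or still open, it means among the compounds named here.

Measured in an ADME assay on microsomes from liver (Homo sapiens) for metabolic stability, with a stated time of 10 min; a lower number here means that less of the compound is left, a higher number that more of the compound is left:

- compound 1 `CC(C)OC(=O)NCCS(=O)(=O)NC(=O)c1ccc(Nc2nc(NC3(c4ccc(Cl)cc4)CC3)nc(OCC(F)(F)F)n2)cc1`: 100%
- compound 2 `O=C(NS(=O)(=O)c1ccccc1)c1ccc(Nc2nc(NC3(c4ccc(Cl)cc4)CC3)nc(OCC(F)(F)F)n2)cc1`: 100%
- compound 3 `CC(C)(C)OC(=O)NCCS(=O)(=O)NC(=O)c1ccc(Nc2nc(NC3(c4ccc(Cl)cc4)CC3)nc(OCC(F)(F)F)n2)cc1`: 92%

Compound 1 stands level with compound 2, the two together the highest of the three numbers; its furthest neighbour is compound 3, a gap that stays within the scatter, a number 8 percentage points lower from compound 1 to compound 3 (within the scatter). Compound 4 `COC(=O)NCCS(=O)(=O)NC(=O)c1ccc(Nc2nc(NC3(c4ccc(Cl)cc4)CC3)nc(OCC(F)(F)F)n2)cc1` differs from compound 1 in one place: methyl in place of isopropyl on an oxygen next to a carbonyl group.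

Among the compounds with values here, two measured steps bear on this. The step from compound 1 to compound 3, at the same oxygen next to the carbonyl group, gave a number 8 percentage points lower from compound 1 to compound 3 (within the scatter). The far larger exchange on the sulfonyl sulfur gave no change at the digits printed from compound 1 to compound 2 (within the scatter). Neither moved the read-out beyond the scatter, so no step beyond the scatter is expected here either, a number 3 percentage points lower from compound 1 to compound 4 (within the scatter).

For compound 4 the expected value in this assay is 97%, within 85% to 100%.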

Compound 4, percent of the compound remaining: 90%
For compound 4 the middle estimate is 7 percentage points above the measured one; the measured number falls inside the stated range.
By their numbers in this assay, from the lowest: compounds 4, 3, 1 and 2 (each within the scatter of the next).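

In this assay, methyl on the oxygen next to a carbonyl group adds a third group at this position, with a number 10 percentage points lower from compound 1 to compound 4 (within the scatter) and a number 2 percentage points lower from compound 3 to compound 4 (within the scatter), so methyl, isopropyl and tert-butyl are not separated here. The 2-((methoxycarbonyl)amino)ethyl group in place of phenyl on a sulfonyl sulfur also stays unresolved, with a number 10 percentage points lower from compound 2 to compound 4 (within the scatter). Nothing measured here gives a reason for these readings. Open, as far as these compounds go, is whether a free amine in place of (methoxycarbonyl)amino, or a carboxylic acid at the end of the chain on the sulfonyl sulfur, would leave this assay within the scatter.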